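Notes on the halogenated phenyl step in this series

The source may report more compounds than this note shows. Statements on the series, on what has been measured and on what is new or still open speak of the compounds shown alone.

Measured so far:
compound 1 `CNc1[nH]c(=O)n(O)c(=O)c1C(=O)NCc1ccccc1`: 0.8 uL/min
compound 2 `CCNc1[nH]c(=O)n(O)c(=O)c1C(=O)NCc1ccccc1`: < 0.1 uL/min

Of the compounds shown here, two have been measured in an ADME assay on microsomes from liver (Homo sapiens) for metabolic stability; on this read-out higher numbers stand for fast clearance and lower numbers for slow clearance. Compound 1 gives 0.8 uL/min in this assay. Compound 2 returns only a limit of this assay, < 0.1 uL/min, as recorded in the limit of < 0.1 uL/min in this assay, at which 1 of the 2 values shown sits. Among the compounds with values here, the one measured step, an at least 8.0-fold lower number from compound 1 to compound 2 (0.90 log units; beyond the scatter), concerns methyl in place of hydrogen on a saturated chain carbon bound to a nitrogen on an aromatic ring; it leaves the phenyl untouched.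

Compound 3 `CCNc1[nH]c(=O)n(O)c(=O)c1C(=O)NCc1cccc(Cl)c1F` is not yet measured. It differs from compound 2 by 3-chloro-2-fluorophenyl in place of phenyl on a saturated chain carbon bound to an amide-type nitrogen. Within the data shown here, no measured step bears on the phenyl or on a 3-chloro-2-fluorophenyl, so no step beyond the scatter is expected in this assay in either direction; the expected step is a number no lower from compound 2 to compound 3 (the limit leaves the size open). For compound 3 the estimate in this assay is 0.1 uL/min, in the range 0.04 uL/min to 0.3 uL/min, with a fair chance that again only a limit is reported.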

Compound 3, intrinsic clearance in a liver preparation (reported as CLH), per the amount of preparation that the assay uses in the Homo sapiens assay: < 0.1 uL/min
Compound 3: a limit, no number; the forecaster's own chance of this, stated with the estimate: 60%; the middle value sits exactly at the limit.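

In a physicochemical assay for pharmacokinetics (on this read-out higher numbers stand for a longer-lived compound and lower numbers for a shorter-lived compound), compound 2 gives > 24 h, a limit of the assay. In the physicochemical assay compound 3 gives > 24 h, also a limit. Within the data shown here, compound 2 and compound 3 sit at limits in both the Homo sapiens assay and the physicochemical assay, so no step between them can be read. Going by these compounds, whether 3-chloro-2-fluorophenyl in place of phenyl changes either read-out at all remains open.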